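The source may report more compounds than this note shows. Statements on the series, on what has been measured and on what is new or still open speak of the compounds shown alone.

Measured compounds:
- compound 1 `CC(C)c1c(C(=O)N2CCCC2c2ccccc2)nn(-c2ccc(F)cc2)c1OC[C@@H](O)C[C@@H](O)CC(=O)O` in a functional assay on L6 cells (Rattus norvegicus) for inhibition (on this read-out lower numbers stand for stronger inhibition and higher numbers for weaker inhibition), gives 4340 nM
- compound 2 `COc1ccc(CNC(=O)c2nn(-c3ccc(F)cc3)c(OC[C@@H](O)C[C@@H](O)CC(=O)O)c2C(C)C)cc1` in this assay gives "not determined" (no result reported)

Within the data shown here, compound 1 is the only compound of this set with a number in this assay, so it stands alone and there is no measured step against which to judge it; compound 2 shares the same core but brings no number to compare. Compound 3 `CC(C)c1c(C(=O)N(C)Cc2cccc(Cl)c2)nn(-c2ccc(F)cc2)c1OC[C@@H](O)C[C@@H](O)CC(=O)O` is the unmeasured partner of compound 1. The difference between the two is (3-chlorobenzyl)(methyl)amino in place of 2-phenylpyrrolidin-1-yl on a carbonyl carbon, an exchange of one amide substituent for another while the rest of the molecule, including the acid-bearing side chain, is kept. Among the measured compounds shown here, with no measured step of this kind available, the most cautious expectation is a step from compound 1 to compound 3 that stays within the usual scatter, or at most a modest one in either direction. On that basis the value expected for compound 3 in this assay is 3500 nM, with a range from 800 nM to 15000 nM, which is expected to correspond to a step of a 1.2-fold lower number from compound 1 to compound 3 (0.09 log units; within the scatter).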

Compound 3, half-maximal inhibitory concentration: 2120 nM
Estimate against measurement, compound 3: 1.7-fold (0.22 log units) above, and the stated range covers the measured number.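

In this assay, among these compounds, putting (3-chlorobenzyl)(methyl)amino in place of 2-phenylpyrrolidin-1-yl on the carbonyl carbon gives a 2.0-fold lower number from compound 1 to compound 3 (0.31 log units; beyond the scatter), the only measured step in this set. It shows that this position tolerates a change of amide substituent, and that the five-membered non-aromatic ring of compound 1 is not needed for inhibition in this assay, since compound 3 lacks that ring and still gives the lower number. The step is modest, and nothing available explains why the number moves in this direction.

Several things change at once in this exchange, so it remains open which one carries the step: the loss of the ring, the chlorine or the methyl on the amide nitrogen, and a benzyl(methyl)amino group without the chlorine would help to separate them. Also open, as far as these compounds go, is how the position responds to quite different substituents, such as a 2-phenylethyl group with its longer chain or a benzyl group bearing a dimethylamino substituent.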